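A Lactam in Place of a Phenol on a Thiophene Amide

The source may report more compounds than this note shows. Statements on the series, on what has been measured and on what is new or still open speak of the compounds shown alone.

Of the compounds shown here, two have been measured in an assay on cells for positive allosteric modulation of Cystic fibrosis transmembrane conductance regulator variant F508del (Homo sapiens), with stated times of 10 min and 7 s, in the presence of a further agent that is not named here; a lower number here means that less compound is needed, a higher number that more compound is needed for the effect. Compound 1 `Cc1ccc(C(=O)Nc2sc3c(c2C(N)=O)CCOC3)s1` gives 778 nM in this assay. Compound 2 `CC1(C)Cc2c(sc(NC(=O)c3ccccc3O)c2C(N)=O)C(C)(C)O1` gives 4 nM in this assay, the lowest of the two numbers; the gap between it and compound 1 lies beyond the usual scatter. For the measured compounds named here, the two compounds differ in more than one place, so no single step between them can be read from these values.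

Compound 3 `CC1(C)Cc2c(sc(NC(=O)C3CCNC3=O)c2C(N)=O)C(C)(C)O1` has not yet been measured. Compared with compound 2 it carries a (2-oxopyrrolidin-3-yl in place of 2-hydroxyphenyl on a carbonyl carbon). The aromatic ring that compound 2 bears on the amide carbonyl is thus replaced by a small saturated lactam, and nothing in the two measured values shows how this assay responds to such an exchange. Because compound 2 sits at 4 nM with a wide gap to compound 1, there is more room upward than downward, and an increase in the number is expected, with the step from a 50-fold higher number from compound 2 to compound 3 (1.70 log units; beyond the scatter). Compound 3 is therefore estimated at 200 nM in this assay, within a range from 20 nM to 3000 nM.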

Compound 3, half-maximal effective concentration: 101 nM
Compound 3: middle estimate off by 2.0-fold (0.30 log units), on the high side; the range from low to high includes it.
By their numbers in this assay, from the lowest: compound 2; then compound 3; then compound 1.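

In this assay, for the compounds shown here, the exchange of 2-hydroxyphenyl for 2-oxopyrrolidin-3-yl on a carbonyl carbon gives the first step that can be read at a single place, a 25-fold higher number from compound 2 to compound 3 (1.40 log units; beyond the scatter), so this position is sensitive to the group it carries. The step occurs although the two groups have the same printed counts of hydrogen-bond donors and acceptors and neither carries a net charge, so equal counts do not keep the number unchanged here. Compound 3 still gives 101 nM with a five-membered non-aromatic ring in place of the six-membered aromatic ring of carbon only, which shows that a measurable effect at this position does not depend on that aromatic ring.

The compounds shown do not separate the loss of the aromatic ring from the loss of its hydroxy group, and they do not tell where a plain phenyl, a 2-aminophenyl or a 2-oxopiperidin-3-yl group on this carbonyl would fall relative to compound 2 and compound 3. No measurement of any property of these compounds is at hand that bears on the reason for this step.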